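The compounds below may be only part of what the source reports. "The series", "measured", "known", "first", "only" and "open" are said of these compounds alone.

Compound 2, `CN(C)Cc1nnc(-c2ccco2)n1-c1ccc(Cl)cc1C(=O)c1ccccc1`, and compound 1, `NCC(=O)Nc1ccc(Cl)cc1C(=O)c1ccccc1`, share the same core and were both examined in a functional assay on the whole organism (strain CF-1) for inhibition, with Mus musculus as the target; on this read-out lower numbers stand for an effect already at smaller amounts and higher numbers for an effect only at larger amounts of compound. In this assay compound 1 gives 0.25 mg/kg, while compound 2 gives 16 mg/kg. Of the two numbers, compound 2 thus holds the higher one, and the gap to compound 1 lies well beyond the usual scatter of repeated measurements. Among the measured compounds shown here, no step between a closely matched pair of measured compounds is available, so the weight of any single structural change on the read-out cannot be taken from these two values alone.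

Compound 3, `Cc1nnc(CN(C)C)n1-c1ccc(Cl)cc1C(=O)c1ccccc1`, has not yet been measured. It differs from compound 2 in one place: methyl in place of furan-2-yl on an aromatic carbon. For the measured compounds named here, with no measured pair to lean on, the direction of the step is open; a moderate change in either sense, or none beyond the scatter, would fit what is known. Compound 3 is therefore expected to land near 10 mg/kg, within a range from 3 mg/kg to 40 mg/kg. That estimate corresponds to a step of a 1.6-fold lower number from compound 2 to compound 3 (0.20 log units; within the scatter), which the eventual measurement will confirm or correct.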

Compound 3, dose for half-maximal effect: 0.5 mg/kg
Estimate against measurement, compound 3: 20-fold (1.30 log units) above; measured number outside the range, below it.
By their numbers in this assay, from the lowest: compounds 1 and 3 (each within the scatter of the next); then compound 2.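

In this assay, this first closely matched pair gives a 32-fold lower number from compound 2 to compound 3 (1.51 log units; beyond the scatter), showing that the group on this aromatic carbon, between two ring nitrogen atoms, carries real weight on the read-out, something the earlier comparison between less closely related compounds could not show. The change removes furan-2-yl, a five-membered aromatic ring with 5 heavy atoms, and puts methyl, with 1 heavy atom and no ring, in its place, so here the lower number goes with the smaller group, although a single pair cannot establish a trend or separate the loss of the ring from the loss of its oxygen. Nothing measured alongside this result explains the step, so its origin remains unassigned.

The compounds shown leave open how a hydrogen, an ethyl group or a phenyl ring on this carbon would read, and thus whether the number follows the count of heavy atoms, the presence of a ring or the ring oxygen. Going by these compounds, the (dimethylamino)methyl group is the same in compound 2 and compound 3, and the effect of an aminomethyl group or a morpholin-4-ylmethyl group in its place remains unknown.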